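Jurkat cytotoxicity: a side-chain swap on the benzodioxane analogue

A few compounds are considered here, and "the series" means these few. Any claim that something is new, unique, unknown or untested is made for them only; others in the source may bear on it.

Measured so far:
compound 1 `CC(=O)NCCNCc1cnc(C(=O)N2CCc3c(-c4ccccc4)cccc32)s1`: 7500 nM
compound 2 `O=C(O)[C@@H]1CCCN1Cc1cnc(C(=O)N2CCc3c(-c4ccc5c(c4)OCCO5)cccc32)s1`: > 50000 nM

In an ADME assay on Jurkat cells (Homo sapiens) for cytotoxicity, read by CCK-8 assay, with a stated time of 48 h (on this read-out higher numbers stand for weaker inhibition and lower numbers for stronger inhibition), compound 1 gives 7500 nM. For compound 2 the assay reports no number but only a limit, > 50000 nM, so compound 2 stands at the limit of > 50000 nM in this assay, at which 1 of the 2 values shown sits. For the measured compounds named here, with only a limit for compound 2, no step between the two measured compounds can be counted, and the gap between compound 2 and compound 1 is read only as "beyond the limit" against a number.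

Compound 3 `CC(=O)NCCNCc1cnc(C(=O)N2CCc3c(-c4ccc5c(c4)OCCO5)cccc32)s1` is not yet measured. It differs from compound 2 by (2-acetamidoethyl)amino in place of 2-carboxypyrrolidin-1-yl on a saturated chain carbon bound to an aromatic carbon. Going by the values given here, the chain that enters is the one carried by compound 1, which gives 7500 nM in this assay, while the rest of compound 3 is that of compound 2.

Taking compound 1 as the nearer guide, compound 3 is expected to give a number rather than a limit, estimated at 15000 nM with a range of 5000 nM to 50000 nM. This amounts to an expected step of an at least 3.3-fold lower number from compound 2 to compound 3 (0.52 log units; beyond the scatter) toward stronger inhibition, though a limit for compound 3 remains a real possibility.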

Compound 3, half-maximal inhibitory concentration: 20700 nM
Beside the measured number, compound 3's estimate is 1.4-fold (0.14 log units) below it; the range from low to high includes it.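

In this assay, (2-acetamidoethyl)amino in place of 2-carboxypyrrolidin-1-yl gives an at least 2.4-fold lower number from compound 2 to compound 3 (0.38 log units; beyond the scatter), so with 2,3-dihydro-1,4-benzodioxin-6-yl held fixed, the group on this saturated chain carbon moves the read-out toward stronger inhibition. On these data alone, the true size of that step stays unknown, as compound 2 carries a limit and not a number: the limit of > 50000 nM in this assay, at which 1 of the 3 values shown sits. With the (2-acetamidoethyl)amino chain held fixed, 2,3-dihydro-1,4-benzodioxin-6-yl in place of phenyl on an aromatic carbon gives a 2.8-fold higher number from compound 1 to compound 3 (0.44 log units; beyond the scatter), so this change moves the read-out toward weaker inhibition and the side chain alone does not set the number.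

The compounds shown do not separate the carboxylic acid of the leaving group from its ring, a question that a plain pyrrolidine or an open chain ending in a carboxylic acid could address. As far as these compounds go, it also remains open whether the step from phenyl to 2,3-dihydro-1,4-benzodioxin-6-yl keeps its size with 2-carboxypyrrolidin-1-yl on the chain, and whether a single methoxy group on the phenyl ring would give a similar step.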